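The source may hold more compounds than are shown below. What is called first, only, known or untested is meant among the compounds shown, and "the series" means these compounds.

Working notes on the series. The shared core is that of compound 1 `Cc1cccc(-n2cc(-c3ccccc3NS(=O)(=O)c3c[nH]c(=O)[nH]c3=O)nn2)c1`, which carries a 3-methylphenyl on the aromatic nitrogen of the triazole-type ring; in a functional assay on OVCAR-3 cells (Homo sapiens) for antiproliferative activity, read by MTT assay, with a stated time of 24 h (on this read-out lower numbers stand for stronger inhibition and higher numbers for weaker inhibition), compound 1 gives 3150 nM. Compound 2 `O=c1[nH]cc(S(=O)(=O)Nc2ccccc2-c2cn(-c3cccc(F)c3)nn2)c(=O)[nH]1` carries 3-fluorophenyl there. In this assay compound 2 reaches only the limit > 20000 nM. Compound 3 `O=c1[nH]cc(S(=O)(=O)Nc2ccccc2-c2cn(-c3ccc(F)cc3)nn2)c(=O)[nH]1` carries 4-fluorophenyl. In this assay compound 3 likewise sits at the limit > 20000 nM. Compound 3 therefore stands at the weak end of the three values shown, together with compound 2, both at the limit of > 20000 nM in this assay, at which 2 of the 3 values shown sit.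

Going by the values given here, the steps that bear on the aryl change are an at least 6.3-fold higher number from compound 1 to compound 3 (0.80 log units; beyond the scatter) and an at least 6.3-fold higher number from compound 1 to compound 2 (0.80 log units; beyond the scatter); the step that the two limits leave unreadable from compound 2 to compound 3 cannot be read, since both ends are limits.

Compound 4 `O=c1[nH]cc(S(=O)(=O)Nc2ccccc2-c2cn(-c3cccc(Cl)c3)nn2)c(=O)[nH]1` differs from compound 3 by 3-chlorophenyl in place of 4-fluorophenyl on an aromatic nitrogen. The 3-chlorophenyl resembles the 3-methylphenyl of compound 1 more than either fluorophenyl does, so a number nearer that of compound 1 than to the limit of compound 3 is expected, though the direction of the fluoro-to-methyl steps leaves this uncertain. The expected step is an at least 2.5-fold lower number from compound 3 to compound 4 (0.39 log units; beyond the scatter). Compound 4 is estimated at 8000 nM, with a range of 2500 nM to 25000 nM.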

Compound 4, half-maximal inhibitory concentration: 2180 nM
Estimate against measurement, compound 4: 3.7-fold (0.56 log units) above; measured number below the stated range.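

The new value shows that a halogen on this phenyl ring need not cost activity: in this assay, chloro in place of fluoro gives an at least 9.1-fold lower number from compound 2 to compound 4 (0.96 log units; beyond the scatter), and 3-chlorophenyl in place of 4-fluorophenyl gives an at least 9.1-fold lower number from compound 3 to compound 4 (0.96 log units; beyond the scatter). Chloro in place of methyl gives a 1.4-fold lower number from compound 1 to compound 4 (0.16 log units; within the scatter), so compound 4 and compound 1 cannot be told apart, and the methyl of compound 1 is not the only group on this ring that gives a measurable number. Compound 2 and compound 3 remain at a limit of the assay, not at a number: the limit of > 20000 nM in this assay, at which 2 of the 4 values shown sit.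

The step between compound 2 and compound 3 cannot be read, so the compounds shown do not separate the two fluorophenyl groups. Also open, going by these compounds, is how bromo, methoxy or an amine on this phenyl ring would compare with chloro and methyl.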